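Swapping the Ring Amine for Diethylamino in Compound 4

The compounds below may be only part of what the source reports. "The series", "measured", "known", "first", "only" and "open" are said of these compounds alone.

Compound 1 `O=C(CNc1nc(N2CCc3ccccc3C2)nc2ccccc12)NCc1ccccc1` is tested in an ADME assay on A549 cells (Homo sapiens) for cytotoxicity, read by CCK-8 assay, with a stated time of 48 h (on this read-out higher numbers stand for lower toxicity in this test and lower numbers for higher toxicity in this test), where compound 1 gives 12800 nM. Of the two numbers shown, compound 1 stands highest, but its nearest neighbour is close. Compound 3 `O=C(CNc1nc(N2CCc3ccccc3C2)nc2ccccc12)Nc1ccccc1` gives 10700 nM. The step of a 1.2-fold lower number from compound 1 to compound 3 (0.08 log units; within the scatter) puts phenyl in place of benzyl on an amide-type nitrogen and lies within the scatter. Compound 2 `CCN(CC)c1nc(SCC(=O)Nc2ccccc2)c2ccccc2n1` reaches only the limit of the test, > 100000 nM (the limit of > 100000 nM in this assay, at which 1 of the 3 values shown sits).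

Compound 4 `CCN(CC)c1nc(NCC(=O)NCc2ccccc2)c2ccccc2n1` differs from compound 1 by diethylamino in place of 1,2,3,4-tetrahydroisoquinolin-2-yl on an aromatic carbon. Among the compounds with values here, no measured step covers this change directly; the only measured step, from compound 1 to compound 3, touches a different part of the molecule and stays within the scatter. Compound 2 also carries diethylamino on the shared core and gives only a limit. A higher number than that of compound 1 is thus expected for compound 4. For compound 4 the expected step is a 3.1-fold higher number from compound 1 to compound 4 (0.49 log units; beyond the scatter). Compound 4 is estimated at 40000 nM, with a range from 12000 nM to 100000 nM, and a real chance that only a limit is reported.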

Compound 4, half-maximal cytotoxic concentration: > 100000 nM
Compound 4: only a limit was reported; the forecaster's own chance of this, stated with the estimate: 40%; middle value at least 2.5-fold (0.39 log units) away from the limit.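

Putting diethylamino in place of 1,2,3,4-tetrahydroisoquinolin-2-yl on this aromatic carbon gives an at least 7.8-fold higher number from compound 1 to compound 4 (0.89 log units; beyond the scatter) in this assay, which means lower toxicity in this test. The earlier step, a 1.2-fold lower number from compound 1 to compound 3 (0.08 log units; within the scatter), changed a different part of the molecule, so this is the first single change shown to move the read-out beyond the scatter. Only the smallest possible size of the new step can be read, because the value of compound 4 is a limit and not a number: the limit of > 100000 nM in this assay, at which 2 of the 4 values shown sit.

As far as these compounds go, it remains open which part of 1,2,3,4-tetrahydroisoquinolin-2-yl the read-out depends on; piperidin-1-yl, a ring amine without the aromatic ring, would help to separate the two rings. Also open, from the compounds shown here alone, is whether the same swap on compound 3 would give a step of similar size.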